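The compounds below may be only part of what the source reports. "The series", "measured", "known", "first", "only" and "open" are said of these compounds alone.

Three compounds share one core and differ only in small groups along a flexible linker. In a functional assay on MDA-MB-231 cells (Homo sapiens) for inhibition, read by MTT assay, with a stated time of 72 h (a lower number here means a stronger inhibitor, a higher number a weaker inhibitor), compound 1 `CC1=C(CCC(=O)OCCCCOc2no[n+]([O-])c2S(=O)(=O)c2ccccc2)C(=O)c2c(O)cccc2C1=O` gives 1240 nM. Compound 2 `CC1=C(C(C)CC(=O)OCCCCOc2no[n+]([O-])c2S(=O)(=O)c2ccccc2)C(=O)c2c(O)cccc2C1=O` gives 1980 nM, and compound 3 `CC1=C(C(C)CC(=O)OCC(C)COc2no[n+]([O-])c2S(=O)(=O)c2ccccc2)C(=O)c2c(O)cccc2C1=O` gives 2110 nM. Compound 3 thus stands at the top of the three numbers, yet its gaps to compound 2 and to compound 1 are both within the usual scatter, so none of the three can be told apart with confidence.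

Compound 4 `CC1=C(CCC(=O)OCC(C)COc2no[n+]([O-])c2S(=O)(=O)c2ccccc2)C(=O)c2c(O)cccc2C1=O` is compound 3 with one change: hydrogen in place of methyl on a saturated chain carbon bound to a double-bonded ring carbon and a saturated chain carbon. The same place has been altered once before among the measured compounds, in the opposite direction: a 1.6-fold higher number from compound 1 to compound 2 (0.20 log units; within the scatter). Undoing that change in compound 3 therefore gives no ground to expect a shift in this assay beyond the scatter, perhaps only a slight move toward a lower number. The step expected is a 1.4-fold lower number from compound 3 to compound 4 (0.15 log units; within the scatter). For compound 4 the estimate in this assay is 1500 nM, with a range from 800 nM to 2800 nM.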

Compound 4, half-maximal inhibitory concentration: 2670 nM
Compound 4: the middle estimate sits 1.8-fold (0.25 log units) below what was measured; low and high end bracket the measured number.
By their numbers in this assay, from the lowest: compounds 1, 2, 3 and 4 (each within the scatter of the next, the first and the last beyond it).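

In this assay, hydrogen in place of methyl on the branched chain of compound 3 gives a 1.3-fold higher number from compound 3 to compound 4 (0.10 log units; within the scatter). Among these compounds, this position can now be read on a second chain, which the single earlier step could not offer. On neither chain does exchanging hydrogen and methyl move the number beyond the scatter, and the two readings of this change also agree within the scatter: the same change on two cores in this assay, a 1.6-fold higher number (0.20 log units; within the scatter) from compound 1 to compound 2 and a 1.3-fold lower number (0.10 log units; within the scatter) from compound 4 to compound 3, 2.0-fold (0.31 log units) apart, within the scatter of two such steps

At this saturated chain carbon, only hydrogen and methyl appear among the compounds shown, so these results give no reading of a larger group such as ethyl or phenyl, or of a hydroxyl or an amine. Going by these compounds, whether any such group would shift the number beyond the scatter remains open.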